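Series notes: 1-methylbutoxy to butoxy on the carbonyl-bound ring

The compounds below may be only part of what the source reports. "The series", "measured", "known", "first", "only" and "open" are said of these compounds alone.

Going by the values given here, compound 2 `CCCC(C)Oc1ccc(C(=O)/C=C/c2c(/C=C/c3ccc(OC)cc3)cc(OC)cc2OC)cc1` gives 11.1 ug/mL in a functional assay on HepG2 cells (Homo sapiens) for antiproliferative activity, read by MTT assay, with a stated time of 48 h (on this read-out higher numbers stand for weaker inhibition and lower numbers for stronger inhibition), the lowest of the two numbers in hand, with compound 1 `COc1ccc(/C=C/c2cc(OC)cc(OC)c2/C=C/C(=O)c2cccc(OC)c2)cc1` nearest at 11.6 ug/mL; the only measured step, a 1.0-fold lower number from compound 1 to compound 2 (0.02 log units; within the scatter), lies within the scatter. Compound 3 `CCCCOc1ccc(C(=O)/C=C/c2c(/C=C/c3ccc(OC)cc3)cc(OC)cc2OC)cc1` differs from compound 2 by hydrogen in place of methyl on a saturated chain carbon bound to an oxygen on an aromatic ring and a saturated chain carbon. Among the compounds with values here, no measured step touches this chain; the single step available exchanges the group on the carbonyl carbon and stays within the scatter, so no step beyond the scatter is expected in this assay. For compound 3 the estimate is 11 ug/mL, with a range from 5.5 ug/mL to 22 ug/mL. The expected step is therefore a 1.0-fold lower number from compound 2 to compound 3 (0.00 log units; within the scatter).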

Compound 3, half-maximal inhibitory concentration: 12.9 ug/mL
For compound 3 the middle estimate is 1.2-fold (0.07 log units) below the measured one; the range from low to high includes it.
By their numbers in this assay, from the lowest: compounds 2, 1 and 3 (each within the scatter of the next).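

The change from 1-methylbutoxy to butoxy in this assay gives no readable step (a 1.2-fold higher number from compound 2 to compound 3 (0.07 log units; within the scatter)), so this saturated chain carbon accepts hydrogen in place of methyl without a difference beyond the scatter. The butoxy chain also stays level with the 3-methoxyphenyl group (a 1.1-fold higher number from compound 1 to compound 3 (0.05 log units; within the scatter)), as the 1-methylbutoxy chain did. No measurement on hand offers an explanation for these results. Still open, from the compounds shown here alone, is whether a longer chain, or an amine or a carboxylic acid at the chain end, would give a step beyond the scatter.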